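Working notes: carbonyl substituent variation, compound 4

A few compounds are considered here, and "the series" means these few. Any claim that something is new, unique, unknown or untested is made for them only; others in the source may bear on it.

Three compounds with a shared core have numbers in an assay on COS-1 cells for displacement of a labelled ligand from sodium-dependent dopamine transporter (Homo sapiens); a lower number here means a stronger inhibitor, a higher number a weaker inhibitor. Compound 1 `CON(C)C(=O)C1=C(c2ccc(Cl)c(Cl)c2)CCC1` gives 6400 nM. Compound 2 `O=C(NCc1cccs1)C1=C(c2ccc(Cl)c(Cl)c2)CCC1` gives 140 nM. Compound 3 `CC(C)OC(=O)C1=C(c2ccc(Cl)c(Cl)c2)CCC1` gives 2600 nM, the second highest of the three; it sits close to compound 1, the step being a 2.5-fold lower number from compound 1 to compound 3 (0.39 log units; beyond the scatter), and far from compound 2, the step being a 19-fold higher number from compound 2 to compound 3 (1.27 log units; beyond the scatter).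

Compound 4 `O=C(OCCF)C1=C(c2ccc(Cl)c(Cl)c2)CCC1` differs from compound 3 by 2-fluoroethyl in place of isopropyl on an oxygen next to a carbonyl group. For the measured compounds named here, no measured step keeps an oxygen on the carbonyl group and changes only what sits on it; every step so far exchanges the whole group on the carbonyl carbon, as in a 46-fold lower number from compound 1 to compound 2 (1.66 log units; beyond the scatter). Going by the values given here, the smallest of those, a 2.5-fold lower number from compound 1 to compound 3 (0.39 log units; beyond the scatter), is already a larger structural change than the one from compound 3 to compound 4, so the data give no ground for a step beyond the scatter here.

Compound 4 is therefore expected near compound 3 in this assay, estimated at 2600 nM with a range of 1000 nM to 7000 nM. The expected step is no change at the digits printed from compound 3 to compound 4 (within the scatter).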

Compound 4, inhibition constant: 500 nM
Compound 4: middle estimate off by 5.2-fold (0.72 log units), on the high side, outside the stated range (below it).
By their numbers in this assay, from the lowest: compound 2; then compound 4; then compound 3; then compound 1.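

In this assay the group on an oxygen next to a carbonyl group affects the number on its own, with the carbonyl substituent otherwise kept: a 5.2-fold lower number from compound 3 to compound 4 (0.72 log units; beyond the scatter) follows from 2-fluoroethyl in place of isopropyl, with the heavy-atom count unchanged. Among the compounds with a group on that oxygen, compound 4 comes closer to the amide of compound 2, with a 3.6-fold higher number from compound 2 to compound 4 (0.55 log units; beyond the scatter) still remaining, and it stands well clear of compound 1, with a 13-fold lower number from compound 1 to compound 4 (1.11 log units; beyond the scatter) separating them. Nothing measured on these compounds accounts for the step.

Still open, on these data alone, is whether the fluorine or the change from a branched to a straight chain carries the step, which an ethyl group on the same oxygen would separate. Also open, as far as these compounds go, is how a longer chain such as 3-fluoropropyl on that oxygen, or 2-fluoroethyl on an amide nitrogen, would compare with compound 4 and compound 2.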